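Swapping a halogenated phenyl ring on an acetonide core

A few compounds are considered here, and "the series" means these few. Any claim that something is new, unique, unknown or untested is made for them only; others in the source may bear on it.

Four compounds share a hydrazone-bearing lactam linked through a triazole to a sugar-derived part. Compound 1 `CC(=O)C[C@H]1O[C@@H](On2cc(CN3C(=O)/C(=N\Nc4ccc(F)cc4)c4ccccc43)nn2)[C@H](OC(C)=O)[C@@H](OC(C)=O)[C@H]1OC(C)=O` carries a 4-fluorophenyl group and an acetylated sugar; compound 2 `CC(=O)C[C@H]1O[C@@H](On2cc(CN3C(=O)/C(=N\Nc4cccc(Cl)c4)c4ccccc43)nn2)[C@H](OC(C)=O)[C@@H](OC(C)=O)[C@H]1OC(C)=O` differs from it by 3-chlorophenyl in place of 4-fluorophenyl on an amine nitrogen. In an ADME assay on Vero cells (Chlorocebus sabaeus) for cytotoxicity, read by fluorescence and resazurin assay, with a stated time of 3 days (a lower number here means that less compound is tolerated, a higher number that more compound is tolerated), compound 1 gives 78600 nM, and compound 2 gives 87900 nM, so that the change brings a 1.1-fold higher number from compound 1 to compound 2 (0.05 log units; within the scatter). Compound 3 `CC1(C)O[C@H]2O[C@H](Cn3cc(CN4C(=O)/C(=N\Nc5ccc(F)cc5)c5ccccc54)nn3)[C@H](O)[C@H]2O1` keeps the 4-fluorophenyl group but sits on an acetonide-protected core; how that core differs from the core of compound 1 is not broken down here. In this assay compound 3 gives 83800 nM, a number that lies in the same range as compound 1 and compound 2. Compound 4 `CC1(C)O[C@H]2O[C@H](Cn3cc(CN4C(=O)/C(=N\Nc5cccc(Cl)c5)c5ccccc54)nn3)[C@H](O)[C@H]2O1` is the not yet measured partner of compound 3, and it differs from it by 3-chlorophenyl in place of 4-fluorophenyl on an amine nitrogen. For the measured compounds named here, this is the same change as the one from compound 1 to compound 2, made at the same place. The step from compound 3 to compound 4 is therefore expected to be about a 1.1-fold higher number from compound 3 to compound 4 (0.04 log units; within the scatter), because in compound 1 and compound 2 the same change gave a 1.1-fold higher number from compound 1 to compound 2 (0.05 log units; within the scatter). On that basis compound 4 is estimated to give 92000 nM in this assay, with a likely range from 46000 nM to 180000 nM.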

Compound 4, half-maximal cytotoxic concentration: 70000 nM
Estimate against measurement, compound 4: 1.3-fold (0.12 log units) above; low and high end bracket the measured number.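

In this assay, putting 3-chlorophenyl in place of 4-fluorophenyl on the acetonide-protected core gives a 1.2-fold lower number from compound 3 to compound 4 (0.08 log units; within the scatter). Set beside the earlier step, the two cores cannot be told apart for this change: the same change on two cores in this assay, a 1.1-fold higher number (0.05 log units; within the scatter) from compound 1 to compound 2 and a 1.2-fold lower number (0.08 log units; within the scatter) from compound 3 to compound 4, 1.3-fold (0.13 log units) apart, within the scatter of two such steps. This shows that, on these two cores, the swap leaves the number within the scatter, so the result from one core was a fair guide to the result on the other; it does not show that the two cores respond identically, and the apparent up and down of the two small steps carries no meaning.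

Going by these compounds, a change with so little effect is a weak test of transfer, so it remains open whether a phenyl ring carrying an amine or a carboxylic acid in place of the halogen would also behave alike on both cores. On these data alone, whether a third core would follow these two also stays open.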